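The source may hold more compounds than are shown below. What is called first, only, known or untested is meant among the compounds shown, and "the series" means these compounds.

Compound 2 `COc1cc(NC(=O)Nc2cc(Nc3ccc(OC)c(I)c3)ncn2)cc(OC)c1` stands at one of two numbers in a functional assay on NCI-H226 cells (Homo sapiens) for inhibition, read by MTT assay, with a stated time of 48 h, tested at 10 uM; a lower number here means less inhibition, a higher number more inhibition at the concentration tested (going by the name of the read-out); in this assay compound 2 gives 40.1%. For the measured compounds named here, its only measured neighbour is compound 1 `COc1cc(NC(=O)Nc2cc(Nc3ccc(OC)c(C)c3)ncn2)cc(OC)c1`, which in this assay gives 39.7%; the step of a number 0.4 percentage points higher from compound 1 to compound 2 (within the scatter) lies within the scatter, so the two values cannot be ordered. Compound 3 `COc1cc(NC(=O)Nc2cc(Nc3cc(C)cc(F)c3)ncn2)cc(OC)c1` has not yet been measured in this assay. It differs from compound 2 by 3-fluoro-5-methylphenyl in place of 3-iodo-4-methoxyphenyl on a nitrogen on an aromatic ring. Going by the values given here, the one measured step touches the same ring, with iodo in place of methyl on an aromatic carbon, and moved the read-out by a number 0.4 percentage points higher from compound 1 to compound 2 (within the scatter), that is by nothing beyond the scatter. Among the compounds with values here, no measured step alters the methoxy of that ring, so the expectation rests on a thin basis. Compound 3 is therefore expected to stay close, with an estimated step of a number 2.1 percentage points lower from compound 2 to compound 3 (within the scatter), giving an expected 38%, between 25% and 52%.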

Compound 3, a percentage reported as inhibition, at one concentration (the size of the read-out at that concentration, not a potency): 35.3%
Compound 3: middle estimate off by 2.7 percentage points, on the high side, within the range that was stated.
By their numbers in this assay, from the lowest: compounds 3, 1 and 2 (each within the scatter of the next).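

In this assay, exchanging the whole aryl group on the nitrogen comes to a number 4.8 percentage points lower from compound 2 to compound 3 (within the scatter), and exchanging 4-methoxy-3-methylphenyl for the same 3-fluoro-5-methylphenyl comes to a number 4.4 percentage points lower from compound 1 to compound 3 (within the scatter). The earlier pair differed by a single substituent, whereas here the methoxy is gone as well and the read-out at this position still cannot be separated, so the three compounds stand as one group. No measurement shown offers an explanation for how close these values lie.

The compounds shown leave open whether any group on this nitrogen can move the read-out beyond the scatter, for instance an aryl group carrying an amine or a carboxylic acid. They also leave open how these compounds compare in potency, since each was read at a single concentration.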